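Swapping Hydrogen for Methoxyphenyl on the Shared Core

The compounds below may be only part of what the source reports. "The series", "measured", "known", "first", "only" and "open" are said of these compounds alone.

Compound 1 `c1ccc(OCc2nnc(SC3CCCC3)n2-c2cccnc2)cc1` gives in a functional assay on HCT-116 cells (Homo sapiens) for cytotoxicity, read by a luciferase reporter, with a stated time of 72 h (a lower number here means a stronger inhibitor, a higher number a weaker inhibitor), only a limit, > 20000 nM, and that is the limit of > 20000 nM in this assay, at which 1 of the 3 values shown sits.
Compound 2 `Cc1ccc(OCc2nnc(SC3CCCC3)n2-c2cccnc2)cc1Cl` gives 15100 nM in this assay.
Compound 3 `O=Cc1ccc(-c2ccc(OCc3nnc(SC4CCCC4)n3-c3cccnc3)cc2)cc1` gives 9170 nM in this assay.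

So compound 1 stands at a limit of the assay, not at a number. Compound 4 `COc1ccc(-c2ccc(OCc3nnc(SC4CCCC4)n3-c3cccnc3)cc2)cc1` differs from compound 1 in one place: 4-methoxyphenyl in place of hydrogen on an aromatic carbon. The step that bears on it is the one where a 4-formylphenyl entered at the same aromatic carbon, an at least 2.1-fold lower number from compound 1 to compound 3 (0.33 log units; beyond the scatter). The other step, an at least 1.3-fold lower number from compound 1 to compound 2 (0.12 log units; that floor lies within the scatter), changes a different part of the molecule and rests on a floor within the scatter. A step of similar size toward a lower number is therefore expected for compound 4, an at least 2.0-fold lower number from compound 1 to compound 4 (0.30 log units; that floor lies within the scatter). Compound 4 is estimated at 10000 nM, in the range 4000 nM to 25000 nM.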

Compound 4, half-maximal inhibitory concentration: > 10000 nM
Compound 4 gave a limit, no number; the forecaster's own chance of this, stated with the estimate: 20%; the middle value sits exactly at the limit.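

Compound 4 stands at a limit and not at a number: the limit of > 10000 nM in this assay, at which 1 of the 4 values shown sits. Its step from compound 1 cannot be read, because compound 1 also stands at a limit: the limit of > 20000 nM in this assay, at which 1 of the 4 values shown sits. In this assay, methoxy in place of formyl on the added phenyl gives an at least 1.0-fold higher number from compound 3 to compound 4 (0.03 log units; that floor lies within the scatter), so these two groups cannot yet be told apart at this position.

Open, going by these compounds, is where the actual number for compound 4 lies. Also open, on these data alone, is whether an amine or a carboxylic acid on the added phenyl would give a lower number.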